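A few compounds are considered here, and "the series" means these few. Any claim that something is new, unique, unknown or untested is made for them only; others in the source may bear on it.

Working notes on the series built on the core of compound 1 `C[C@H]1CC[C@@H]2[C@@H](OC(=O)[C@]23CC(c2c(Cl)cccc2Cl)=NO3)[C@]2(C)C(=O)C=C[C@@]12O`, read in a functional assay on SW-620 cells (Homo sapiens) for cytotoxicity, read by sulforhodamine B assay, with a stated time of 48 h; a higher number here means a weaker inhibitor, a lower number a stronger inhibitor. Compound 1 gives 43000 nM, compound 2 `C[C@H]1CC[C@@H]2[C@@H](OC(=O)[C@]23CC(c2ccc(N(C)C)cc2)=NO3)[C@]2(C)C(=O)C=C[C@@]12O` gives 5100 nM, and compound 3 `C[C@H]1CC[C@@H]2[C@@H](OC(=O)[C@]23CC(c2ccc([N+](=O)[O-])cc2)=NO3)[C@]2(C)C(=O)C=C[C@@]12O` gives 9000 nM. Compound 3 cannot be separated from compound 2, the gap being a 1.8-fold higher number from compound 2 to compound 3 (0.25 log units; within the scatter). Compound 1 stands apart from compound 2, with an 8.4-fold lower number from compound 1 to compound 2 (0.93 log units; beyond the scatter).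

The next change leads to compound 4 `C[C@H]1CC[C@@H]2[C@@H](OC(=O)[C@]23CC(c2ccccc2Cl)=NO3)[C@]2(C)C(=O)C=C[C@@]12O`: 2-chlorophenyl in place of 4-nitrophenyl on a carbon with a double bond to nitrogen. Among the measured compounds shown here, no 2-chlorophenyl member has been measured yet. For the measured compounds named here, the closest guide is a 4.8-fold lower number from compound 1 to compound 3 (0.68 log units; beyond the scatter), since the 2,6-dichlorophenyl of compound 1 is the only chlorinated aryl group measured so far. Going back along that step, part of the way, points to a higher number in this assay for compound 4, though a smaller move than the full step is expected. The estimated move is a 2.2-fold higher number from compound 3 to compound 4 (0.35 log units; beyond the scatter). For compound 4 the expected value is 20000 nM. The expected range for compound 4 runs from 7000 nM to 50000 nM.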

Compound 4, half-maximal inhibitory concentration: 9000 nM
Beside the measured number, compound 4's estimate is 2.2-fold (0.35 log units) above it; measured number inside the range.
By their numbers in this assay, from the lowest: compounds 2, 3 and 4 (each within the scatter of the next); then compound 1.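

In this assay, a 2-chlorophenyl group at this position cannot be separated from 4-nitrophenyl (no change at the digits printed from compound 3 to compound 4 (within the scatter)) or from 4-(dimethylamino)phenyl (a 1.8-fold higher number from compound 2 to compound 4 (0.25 log units; within the scatter)). The earlier compounds shown here left open whether the number for 2,6-dichlorophenyl applied to chlorinated aryl groups generally, but hydrogen in place of one chloro is enough to move it (a 4.8-fold lower number from compound 1 to compound 4 (0.68 log units; beyond the scatter)). Among the four aryl groups, only 2,6-dichlorophenyl now stands apart, while the other three share no single substituent and remain within the scatter of one another.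

Nothing on hand explains these numbers. The compounds shown leave open how an unsubstituted phenyl, a 4-chlorophenyl or an aryl group carrying a carboxylic acid would read at this position.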